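The compounds below may be only part of what the source reports. "The series", "measured", "known", "first", "only" and "open" are said of these compounds alone.

Measured compounds:
compound 1 `CCOC(=O)c1cnc(-c2ccccc2SC)[nH]c1=O`: in a functional assay on the whole organism (strain Sprague-Dawley) for inhibition, with Rattus norvegicus as the target, with a stated time of 10 min (on this read-out lower numbers stand for an effect already at smaller amounts and higher numbers for an effect only at larger amounts of compound), compound 1 gives > 25 mg/kg, which is a limit of the assay and not a number.
compound 2 `CCOC(=O)c1ccc(OCC)c(-c2ncc(C(=O)OCC)c(=O)[nH]2)c1`: in this assay compound 2 gives 1 mg/kg.

Of the two results shown, compound 2 holds the only number, while the other result sits at the limit of > 25 mg/kg in this assay, at which 1 of the 2 values shown sits. Compound 3 `CCOC(=O)c1cnc(-c2cc(S(=O)(=O)N(C)C(C)C)ccc2OCC)[nH]c1=O` has not yet been measured in this assay. It differs from compound 2 in one place: isopropyl(methyl)sulfamoyl in place of ethoxycarbonyl on an aromatic carbon. Both compounds keep the ethoxy group and the core of compound 2 unchanged.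

Among the compounds with values here, no step between measured compounds is available to set a scale for this exchange. The account therefore rests on compound 2 alone, whose value 1 mg/kg gives the starting point. Compound 1 reached only a limit of the assay. Compound 3 is expected to land close to compound 2, with a step of a 2.0-fold higher number from compound 2 to compound 3 (0.30 log units; within the scatter) of no more than the usual scatter in either direction. The estimate for compound 3 in this assay is 2 mg/kg, with a range from 0.5 mg/kg to 10 mg/kg.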

Compound 3, dose for 50% inhibition: > 10 mg/kg
Compound 3: no number, only a limit; the forecaster's own chance of this, stated with the estimate: 15%; at least 5.0-fold (0.69 log units) between middle value and limit.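

With the ethoxy group and the core unchanged, placing isopropyl(methyl)sulfamoyl instead of ethoxycarbonyl on the aromatic carbon para to the ethoxy group gives an at least 10-fold higher number from compound 2 to compound 3 (1.00 log units; beyond the scatter) in this assay. Within the data shown here, this is the first step available for this position, and it shows that the position does not tolerate every exchange: a group that enters with the same count of hydrogen-bond acceptors as the one that leaves, and with no net charge, still does not keep the result of compound 2. The size of the step has only a lower bound, since the result for compound 3 is a limit of the assay and not a number: the limit of > 10 mg/kg in this assay, at which 1 of the 3 values shown sits.

The compounds shown leave open how far the result of compound 3 lies past that limit, and whether the change follows from the sulfamoyl group as such or from the isopropyl and methyl groups on its nitrogen, which an unsubstituted sulfamoyl or a dimethylsulfamoyl group would separate. They also leave open how a carboxylic acid or a methyl ester on the same carbon would compare with the ethoxycarbonyl group of compound 2.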